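This account rests on a few compounds, and the source may have more. Where it says the series, first, only, none or still open, it means among the compounds named here.

In an ADME assay (liver) for metabolic stability, with Liver microsome (Homo sapiens) as the target, using microsomes, with a stated time of 30 min, tested at 1 uM (a lower number here means that less of the compound is left, a higher number that more of the compound is left), compound 1 (`N#C/N=C(\NCc1ccc(S(=O)(=O)c2cccc(C(F)(F)F)c2)cc1)Nc1ccncc1`) gives 62% and compound 2 (`N#C/N=C(\NCc1ccc(S(=O)(=O)N2CC3CCC(C2)O3)cc1)Nc1ccncc1`) gives 60% so the two measured compounds lie within the scatter of each other. For the measured compounds named here, compound 2 therefore stands level with the only other number available, and neither can be ranked above the other.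

Compound 3 (`N#C/N=C(\NCc1ccc(S(=O)(=O)c2cccc(OC(F)(F)F)c2)cc1)Nc1ccncc1`) keeps the shared core, and the change from compound 2 is a group of 11 heavy atoms (7 carbon, 1 oxygen, 3 fluorine; one six-membered aromatic ring of carbon only) in place of a group of 8 heavy atoms (6 carbon, 1 nitrogen, 1 oxygen; one five-membered non-aromatic ring with 1 hetero atom, one six-membered non-aromatic ring with 2 hetero atoms), on a sulfonyl sulfur with nothing else altered. Going by the values given here, the one measured step that bears on this is a number 2 percentage points lower from compound 1 to compound 2 (within the scatter) and it involves the same group that compound 2 carries, at the same sulfonyl sulfur. The group on that sulfur in compound 1 also has a six-membered aromatic ring of carbon only, although it is not the group entering here. Among the compounds with values here, this single step is indirect evidence, and the data hold no measured step for the 3-(trifluoromethoxy)phenyl group itself.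

In this assay the estimated step is a number 1 percentage points higher from compound 2 to compound 3 (within the scatter) and nothing beyond the scatter is expected. For compound 3 the estimate is 61% with an expected range from 45% to 76% for the measurement.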

Compound 3, percent of the compound remaining: 45%
Estimate against measurement, compound 3: 16 percentage points above; low and high end bracket the measured number.
By their numbers in this assay, from the lowest: compound 3; then compounds 2 and 1 (each within the scatter of the next).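

In this assay, the earlier pair gave no sign that the group on the sulfonyl sulfur matters, but there is now a number 15 percentage points lower from compound 2 to compound 3 (beyond the scatter) when 3-(trifluoromethoxy)phenyl enters in place of the bridged ring group. The smaller change in the same place also counts: with trifluoromethoxy in place of trifluoromethyl on an aromatic carbon, there is a number 17 percentage points lower from compound 1 to compound 3 (beyond the scatter), so having a six-membered aromatic ring of carbon only on the sulfonyl sulfur does not by itself settle the percentage remaining, and the substituent on that ring makes a difference among these compounds. Nothing in the data at hand speaks to what lies behind these differences.

The compounds shown leave open whether a phenyl ring carrying a methoxy group or a chlorine atom in place of the trifluoromethoxy group would stand with compound 1 or with compound 3. They also leave open how a simple amine such as morpholine or piperidine on the sulfonyl sulfur would compare with the bridged ring group of compound 2.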